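A few compounds are considered here, and "the series" means these few. Any claim that something is new, unique, unknown or untested is made for them only; others in the source may bear on it.

Compound 1 `CCOC(=O)[C@H](CCC(=O)O)NC(=O)c1ccc(Sc2nc3cc(N)cc(N)c3nc2-c2ccccc2)cc1`: < 100000 nM
Compound 2 `Nc1cc(N)c2nc(-c3ccccc3)c(Sc3ccc(F)cc3)nc2c1`: < 100000 nM

In a functional assay on SW-620 cells (Homo sapiens) for inhibition, read by sulforhodamine B assay, with a stated time of 48 h (on this read-out lower numbers stand for higher toxicity in this test and higher numbers for lower toxicity in this test), compound 1 gives < 100000 nM, which is a limit of the assay and not a number. In this assay compound 2 gives < 100000 nM, again a limit rather than a measured number. Compound 2 thus stands at the limit at which both shown values sit (the limit of < 100000 nM in this assay, at which 2 of the 2 values shown sit), and nothing in these two values sets it apart from compound 1.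

Compound 3 `Nc1cc(N)c2nc(-c3ccccc3)c(Sc3ccc(Cl)c(Cl)c3)nc2c1` is not yet measured. It differs from compound 2 in one place (3,4-dichlorophenyl in place of 4-fluorophenyl on a sulfur). No step between measured compounds is shown, so the size of this change cannot be read from the data. The step from compound 2 to compound 3 is expected to stay within the scatter, with no clear direction a step that the limit leaves unreadable from compound 2 to compound 3. Compound 3 is expected to give about 30000 nM in this assay, in the range 5000 nM to 100000 nM, and quite possibly to be reported only as a limit again.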

Compound 3, concentration lethal to 50% of the cells: < 100000 nM
Compound 3: a limit, no number (the forecaster's own chance of this, stated with the estimate: 65%); the middle value lies beyond the limit too.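

No step from compound 2 to compound 3 can be read, because both values are limits and not numbers: the limit of < 100000 nM in this assay, at which 3 of the 3 values shown sit.

The compounds shown leave open whether 3,4-dichlorophenyl in place of 4-fluorophenyl on a sulfur changes the result in this assay at all, and in which direction.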